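This account rests on a few compounds, and the source may have more. Where it says the series, first, only, none or still open, it means among the compounds named here.

Measured compounds in a physicochemical assay for solubility, read by spectrophotometry, in phosphate buffer, with a stated time of 2 h, at pH 7.4; on this read-out higher numbers stand for higher solubility and lower numbers for lower solubility:
- compound 1 `COc1ccc2[nH]c(C(=O)N3CC(=O)N(Cc4ccccc4)[C@@H](COc4ccccc4)C3)cc2c1` gives 12200 nM
- compound 2 `COc1ccc2[nH]c(C(=O)N3CC(=O)N(Cc4ccccc4)[C@@H](CN4CC5CCCCC5C4)C3)cc2c1` gives 23800 nM
- compound 3 `COc1ccc2[nH]c(C(=O)N3CC(=O)N(Cc4ccccc4)[C@@H](CN4CCc5ccccc5C4)C3)cc2c1` gives 9000 nM

Compound 3 holds the lowest of the three numbers in this assay. It sits nearest compound 1, a 1.4-fold lower number from compound 1 to compound 3 (0.13 log units; within the scatter), and furthest from compound 2, a 2.6-fold lower number from compound 2 to compound 3 (0.42 log units; beyond the scatter). The remaining measured pair gives a 2.0-fold higher number from compound 1 to compound 2 (0.29 log units; within the scatter).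

Compound 4 `COc1ccc2[nH]c(C(=O)N3CC(=O)N(Cc4ccccc4)[C@@H](CN4CCCc5ccccc54)C3)cc2c1` differs from compound 3 only by 1,2,3,4-tetrahydroquinolin-1-yl in place of 1,2,3,4-tetrahydroisoquinolin-2-yl on a saturated chain carbon bound to a saturated ring carbon. Among the compounds with values here, no measured pair carries this exchange, so the only steps that bear on it are the two that lead into compound 3, one within the scatter and one modest. The two groups are isomers with the same ring count and the same count of donors and acceptors, and the measured series gives no sign that a change of this kind moves the read-out far. For compound 4 in this assay, the expected step is therefore a 1.1-fold lower number from compound 3 to compound 4 (0.02 log units; within the scatter), nothing beyond the scatter. The estimate for compound 4 is 8500 nM, with a range of 3500 nM to 20000 nM.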

Compound 4, solubility: 8500 nM
Compound 4: the middle estimate sits on the measured number at the digits printed; the range from low to high includes it.
By their numbers in this assay, from the lowest: compounds 4, 3, 1 and 2 (each within the scatter of the next, the first and the last beyond it).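

In this assay, 1,2,3,4-tetrahydroquinolin-1-yl in place of 1,2,3,4-tetrahydroisoquinolin-2-yl gives a 1.1-fold lower number from compound 3 to compound 4 (0.02 log units; within the scatter) and so, at this saturated chain carbon, this exchange of the same atoms joined differently does not separate the two compounds on this read-out. The same group in place of phenoxy gives a 1.4-fold lower number from compound 1 to compound 4 (0.16 log units; within the scatter) and, against the saturated group of compound 2, gives a 2.8-fold lower number from compound 2 to compound 4 (0.45 log units; beyond the scatter), so compound 4 joins compound 3 in lying beyond the scatter of compound 2, whereas compound 1 lies within the scatter of all three others. No measurement at hand explains any of these steps.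

Still open, from the compounds shown here alone, is whether a morpholin-4-yl group or a carboxylic acid on this chain carbon would move the number further than these amines and phenoxy do. Also open, going by these compounds, is whether these steps hold when the benzyl group on the shared core gives way to a longer chain.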